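The source may report more compounds than this note shows. Statements on the series, on what has been measured and on what is new or still open speak of the compounds shown alone.

Among the measured compounds shown here, in a functional assay on HUVEC cells (Homo sapiens) for inhibition, with a stated time of 4 days (on this read-out lower numbers stand for stronger inhibition and higher numbers for weaker inhibition), compound 2 `COc1ccc(C(N)=O)cc1/C=C/c1ccc([N+](=O)[O-])cc1` gives 4700 nM and holds the higher of the two numbers so far, while compound 1 `COc1ccc(C(N)=O)cc1/C=C/c1ccc(C(C)(C)C)cc1` gives 370 nM in the same test. Compound 3 `COc1ccc(/C=C/c2cc(C(N)=O)ccc2OC)cc1`, still unmeasured, carries methoxy in place of nitro on an aromatic carbon. For the measured compounds named here, the one measured step at this place is the large change a 13-fold higher number from compound 1 to compound 2 (1.10 log units; beyond the scatter) with nitro in place of tert-butyl, so a step down of similar or smaller size is expected. The estimated change is a 6.7-fold lower number from compound 2 to compound 3 (0.83 log units; beyond the scatter) on this evidence. Compound 3 is expected to read 700 nM (130 nM to 3300 nM).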

Compound 3, half-maximal inhibitory concentration: 8800 nM
Beside the measured number, compound 3's estimate is 13-fold (1.10 log units) below it, outside the stated range (above it).
By their numbers in this assay, from the lowest: compound 1; then compounds 2 and 3 (each within the scatter of the next).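

In this assay methoxy and nitro at this place, para to a large group, cannot be told apart, with a step of a 1.9-fold higher number from compound 2 to compound 3 (0.27 log units; within the scatter). Methoxy in place of tert-butyl gives a 24-fold higher number from compound 1 to compound 3 (1.38 log units; beyond the scatter), so among these three compounds only tert-butyl goes with the clearly lower number. Nothing measured here explains this difference. The compounds shown leave open whether an amine, a carboxylic acid or an ethyl group at this place would read closer to tert-butyl or to the methoxy and nitro pair.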